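Benzoyl to carbamoyl: what the single measured step allows

The compounds below may be only part of what the source reports. "The series", "measured", "known", "first", "only" and "open" are said of these compounds alone.

In a functional assay on K562 cells (Homo sapiens) for antiproliferative activity, read by MTT assay (a higher number here means a weaker inhibitor, a lower number a stronger inhibitor), compound 1 (`O=C1NC(c2ccccc2)CN1S(=O)(=O)c1ccc2c(c1)CCCN2`) stands at > 20000 nM, which is a limit of the assay. For the measured compounds named here, compound 2 (`O=C(c1ccccc1)N1CCCc2cc(S(=O)(=O)N3CC(c4ccccc4)NC3=O)ccc21`) gives 1220 nM, the only actual number so far. Going by the values given here, the one measured step, an at least 16-fold lower number from compound 1 to compound 2 (1.21 log units; beyond the scatter), is large and beyond the scatter, and it places benzoyl in place of hydrogen on a nitrogen on an aromatic ring in a ring.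

Compound 3 (`NC(=O)N1CCCc2cc(S(=O)(=O)N3CC(c4ccccc4)NC3=O)ccc21`) has amino in place of phenyl on a carbonyl carbon, so benzoyl becomes carbamoyl: amino in place of phenyl on a carbonyl carbon. The carbonyl stays and the phenyl goes, and compound 2 and compound 1 do not separate the shares of these two parts. Part of an at least 16-fold lower number from compound 1 to compound 2 (1.21 log units; beyond the scatter) is therefore expected to be lost, giving a higher number in this assay, though a smaller step than that one. The estimated step is a 4.1-fold higher number from compound 2 to compound 3 (0.61 log units; beyond the scatter). For compound 3 the expected value is 5000 nM, with an estimated range of 1500 nM to 20000 nM.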

Compound 3, half-maximal inhibitory concentration: 3660 nM
Beside the measured number, compound 3's estimate is 1.4-fold (0.14 log units) above it, and the stated range covers the measured number.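

Losing the phenyl does not remove the whole gain at this nitrogen: carbamoyl in place of hydrogen still gives an at least 5.4-fold lower number from compound 1 to compound 3 (0.73 log units; beyond the scatter). The phenyl on the carbonyl carbon nevertheless counts in this assay, as replacing it with amino gives a 3.0-fold higher number from compound 2 to compound 3 (0.48 log units; beyond the scatter), so the gain seen with benzoyl now splits into a part kept by carbamoyl and a part that leaves with the phenyl. The part kept by carbamoyl can be stated only as a bound, because compound 1 stands at a limit of the assay: the limit of > 20000 nM in this assay, at which 1 of the 3 values shown sits.

Still open, as far as these compounds go, is whether an acetyl or a cyclohexylcarbonyl group on this nitrogen would fall nearer benzoyl or carbamoyl. The compounds shown also do not separate the amino from the carbonyl itself, a question that a methyl on the carbonyl carbon would bear on.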